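Dipropylamino in place of (3,4-dimethylphenyl)amino

The compounds below may be only part of what the source reports. "The series", "measured", "known", "first", "only" and "open" are said of these compounds alone.

Compound 1 `COc1ccc(NC2=CC(=O)c3nc4n(c3C2=O)[C@H]2OC[C@@H](O)[C@H]2OC4)cc1`: > 4000 nM, a limit of the assay and not a number
Compound 2 `Cc1ccc(NC2=CC(=O)c3nc4n(c3C2=O)[C@H]2OC[C@@H](O)[C@H]2OC4)cc1C`: 2820 nM

Both compounds were tested in a functional assay on ECa-109 cells for inhibition, with ECa-109 cell line (Homo sapiens) as the target, read by sulforhodamine B assay; a lower number here means a stronger inhibitor, a higher number a weaker inhibitor. Among the measured compounds shown here, there, compound 2 at 2820 nM holds the only actual number so far. The result for compound 1 is a limit of the assay.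

The compound now in question is compound 3 `CCCN(CCC)C1=CC(=O)c2nc3n(c2C1=O)[C@H]1OC[C@@H](O)[C@H]1OC3`, which keeps the shared core and differs from compound 2 in one group: dipropylamino in place of (3,4-dimethylphenyl)amino on a double-bonded ring carbon. Dipropylamino stands in place of (3,4-dimethylphenyl)amino on a double-bonded ring carbon.

For the measured compounds named here, only one measured step bears on this, and only loosely: an at least 1.4-fold lower number from compound 1 to compound 2 (0.15 log units; that floor lies within the scatter). Going by the values given here, that step exchanges one substituted phenyl group for another on an amine nitrogen, whereas no measured step removes the aromatic ring. It therefore gives no direction for the new change, and compound 2 at 2820 nM remains the sole anchor.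

The estimated change, a 1.1-fold higher number from compound 2 to compound 3 (0.03 log units; within the scatter), is expected to stay within the scatter. A report of only a limit, as for compound 1, remains possible.

Compound 3 is expected at 3000 nM, with an estimated range from 900 nM to 9000 nM.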

Compound 3, half-maximal inhibitory concentration: > 16000 nM
Compound 3 gave a limit, no number; the forecaster's own chance of this, stated with the estimate: 35%; middle value at least 5.3-fold (0.72 log units) away from the limit.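

In this assay compound 3 gives only a limit of the assay and not a number: the limit of > 16000 nM in this assay, at which 1 of the 3 values shown sits. On a double-bonded ring carbon of the shared core, dipropylamino in place of (3,4-dimethylphenyl)amino produces an at least 5.6-fold higher number from compound 2 to compound 3 (0.75 log units; beyond the scatter), the first step shown at this position that lies beyond the scatter, and its printed size is a floor. The step between compound 1 and compound 3 cannot be read, both of their values being limits.

The change to compound 3 removes the aromatic ring and the hydrogen-bond donor of the amine in one move, so the compounds shown do not separate the two, and they also leave open whether compound 1, with its own limit, belongs with compound 2 or compound 3. A methyl(phenyl)amino group would keep the ring without the amine hydrogen, while a cyclohexylamino group would keep the amine hydrogen without the aromatic ring, and neither group is among the compounds shown here.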